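Dichlorination of the pyridyloxy group in compound 4

The compounds below may be only part of what the source reports. "The series", "measured", "known", "first", "only" and "open" are said of these compounds alone.

Compound 3 `O=C(O)c1ccc2noc(-c3ccc(Oc4ccccn4)cc3)c2c1` stands as the weakest of the three measured compounds in an assay for inhibition of inositol hexakisphosphate kinase 2 (Homo sapiens), read by colorimetric assay, coupled enzyme assay and malachite green, with a stated time of 120 min, in the presence of a further agent that is not named here; a higher number here means a weaker inhibitor, a lower number a stronger inhibitor: compound 3 gives 1190 nM, while compound 1 `O=C(O)c1ccc2noc(-c3ccc(-c4cccnc4)cc3)c2c1` gives 54 nM and compound 2 `O=C(O)c1ccc2noc(-c3ccc(N4CCCCC4)cc3)c2c1` gives 240 nM. The steps that separate them all lie beyond the scatter: a 22-fold higher number from compound 1 to compound 3 (1.34 log units; beyond the scatter), a 5.0-fold higher number from compound 2 to compound 3 (0.70 log units; beyond the scatter), and a 4.4-fold higher number from compound 1 to compound 2 (0.65 log units; beyond the scatter). Compound 4 `O=C(O)c1ccc2noc(-c3ccc(Oc4ncc(Cl)cc4Cl)cc3)c2c1` keeps the core of compound 3 and differs from it in one place: 3,5-dichloropyridin-2-yl in place of pyridin-2-yl on an oxygen on an aromatic ring. Within the data shown here, none of the measured steps bears directly on this change. Each of them exchanges the whole group on the aromatic carbon for a different one, whereas here the oxygen-linked ring is retained and chlorine is added to it. Among the measured compounds shown here, with no measured step that speaks to such an addition, the expected change from compound 3 to compound 4 is a 1.1-fold lower number from compound 3 to compound 4 (0.03 log units; within the scatter), a step not expected to go beyond the scatter in either direction. Compound 4 is therefore estimated at 1100 nM in this assay, with a range from 300 nM to 4000 nM.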

Compound 4, half-maximal inhibitory concentration: 650 nM
Compound 4: the middle estimate sits 1.7-fold (0.23 log units) above what was measured; low and high end bracket the measured number.
By their numbers in this assay, from the lowest: compound 1; then compound 2; then compounds 4 and 3 (each within the scatter of the next).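

In this assay, replacing pyridin-2-yl with 3,5-dichloropyridin-2-yl on the oxygen gives a 1.8-fold lower number from compound 3 to compound 4 (0.26 log units; within the scatter) and so shows that adding the two chlorine atoms to the retained ring does not produce a step beyond the scatter. The oxygen-linked group as a whole remains behind both other groups: there is a 2.7-fold higher number from compound 2 to compound 4 (0.43 log units; beyond the scatter) when it replaces piperidin-1-yl, and a 12-fold higher number from compound 1 to compound 4 (1.08 log units; beyond the scatter) when it replaces pyridin-3-yl. No evidence accompanies these numbers to explain them.

The compounds shown leave open whether a single chlorine on the oxygen-linked ring would read like the two together, and whether a methyl, a methoxy or an amine there would go beyond the scatter. They also leave open what chlorine would do on the pyridin-3-yl group of compound 1.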